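The source may report more compounds than this note shows. Statements on the series, on what has been measured and on what is new or still open speak of the compounds shown alone.

Among the compounds with values here, compound 3 `CCCSCCn1c(=N)sc2cc(OC(F)(F)F)ccc21` gives 2.4 mg/kg in a functional assay on the whole organism with Rattus norvegicus as the target (on this read-out higher numbers stand for an effect only at larger amounts of compound and lower numbers for an effect already at smaller amounts), the lowest of the three numbers so far. Compound 1 `C=CCn1c(=N)sc2cc(OC(F)(F)F)ccc21` gives 7 mg/kg and compound 2 `N=c1sc2cc(OC(F)(F)F)ccc2n1CCS(N)(=O)=O` gives 6 mg/kg in this assay; a 1.2-fold lower number from compound 1 to compound 2 (0.07 log units; within the scatter), while a 2.9-fold lower number from compound 1 to compound 3 (0.46 log units; beyond the scatter) and a 2.5-fold lower number from compound 2 to compound 3 (0.40 log units; beyond the scatter). Compound 4 `N=c1sc2cc(OC(F)(F)F)ccc2n1CCN1CCCCC1` carries piperidin-1-yl in place of propylsulfanyl on a saturated chain carbon, two bonds along the chain from an aromatic nitrogen. Within the data shown here, the steps that bear on this change are the two that vary the same chain end, both modest and both running toward compound 3; no measured step replaces propylsulfanyl with a ring, and the sulfamoyl-bearing compound 2 does not sit far from compound 1. The expected outcome in this assay is therefore a step within the scatter, perhaps a slight rise, estimated as a 1.5-fold higher number from compound 3 to compound 4 (0.16 log units; within the scatter). Compound 4 is expected to give 3.5 mg/kg, with a range of 1.5 mg/kg to 8 mg/kg.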

Compound 4, dose for half-maximal effect: 2 mg/kg
Beside the measured number, compound 4's estimate is 1.8-fold (0.24 log units) above it; the measured number falls inside the stated range.
By their numbers in this assay, from the lowest: compounds 4 and 3 (each within the scatter of the next); then compounds 2 and 1 (each within the scatter of the next).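

In this assay, a piperidin-1-yl ring can replace the open propylsulfanyl chain at this place with no readable change (a 1.2-fold lower number from compound 3 to compound 4 (0.08 log units; within the scatter)), so the two groups cannot be told apart here. Compound 4 also keeps the separation from the sulfamoyl end (a 3.0-fold lower number from compound 2 to compound 4 (0.48 log units; beyond the scatter)) and from the shorter vinyl end (a 3.5-fold lower number from compound 1 to compound 4 (0.54 log units; beyond the scatter)), as compound 3 did. Nothing available explains any of these steps. On these data alone, whether a morpholine ring, an open diethylamino end or a longer chain carrying the piperidin-1-yl ring would hold this level remains open.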